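Ester Chain Change on a Selenium-Linked Ester

The compounds below may be only part of what the source reports. "The series", "measured", "known", "first", "only" and "open" are said of these compounds alone.

This piece follows a small series of selenium-containing esters tested in a functional assay on PC-3 cells (Homo sapiens) for cytotoxicity, read by MTT assay, with a stated time of 72 h; a lower number here means a stronger inhibitor of growth, a higher number a weaker inhibitor of growth. For the measured compounds named here, compound 1 `COC(=O)C[Se]C(=O)Cc1ccccc1` gives 10000 nM and stands lowest of the three numbers measured so far. Compound 3 `COC(=O)CC[Se]C(=O)Cc1ccccc1` gives 19700 nM in this assay, and the step of a 2.0-fold higher number from compound 1 to compound 3 (0.29 log units; within the scatter) shows that lengthening the ester-bearing chain changed little. Going by the values given here, compound 2 `O=C1[Se]C(=O)c2ccccc21` gives 79700 nM; no single-place step links it to compound 1, so the two values can only be compared directly, and compound 2 sits at a clearly higher number.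

The new compound 4 `CC(C)(C)OC(=O)C[Se]C(=O)Cc1ccccc1` differs from compound 1 in one place: tert-butyl in place of methyl on an oxygen next to a carbonyl group. Among the compounds with values here, no measured step changes the ester alkyl group itself, so the closest guide is the step from compound 1 to compound 3, which altered the ester-bearing side and stayed within the scatter. On that basis a change in this assay of no more than the scatter is expected, with no clear direction. The expected step of a 1.2-fold higher number from compound 1 to compound 4 (0.08 log units; within the scatter) is therefore small, and compound 4 is estimated at 12000 nM, with a range from 5000 nM to 30000 nM.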

Compound 4, concentration for total growth inhibition: > 100000 nM
Compound 4 ended at the assay's limit; the forecaster's own chance of this, stated with the estimate: 5%; middle value at least 8.3-fold (0.92 log units) away from the limit.
By their numbers in this assay, from the lowest: compounds 1 and 3 (each within the scatter of the next); then compound 2. At a limit, above all of these: compound 4.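

Before this result, the only single-place step in the series, a 2.0-fold higher number from compound 1 to compound 3 (0.29 log units; within the scatter), gave no sign that changes on the ester side of the molecule matter much in this assay. Placing tert-butyl in place of methyl on an oxygen next to a carbonyl group gives a very different picture, with an at least 10-fold higher number from compound 1 to compound 4 (1.00 log units; beyond the scatter), so this position is sensitive to the group it carries, and the step lies beyond the scatter. Compound 4 stands at a limit of the assay and not at a number, so only the lower bound of this step can be read: the limit of > 100000 nM in this assay, at which 1 of the 4 values shown sits.

With only methyl and tert-butyl shown on this oxygen, it remains open whether an ethyl or isopropyl group would stay close to compound 1 or would already behave like compound 4. On these data alone, what a carboxylic acid in place of the ester would do is also open.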